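Swapping the Ring Tail on the Urea Phenyl for Diethylamino

This account rests on a few compounds, and the source may have more. Where it says the series, first, only, none or still open, it means among the compounds named here.

Of the compounds shown here, two of a shared core have been tested in a functional assay on A-431 cells (Homo sapiens) for antiproliferative activity, read by MTT assay, with a stated time of 72 h; on this read-out higher numbers stand for weaker inhibition and lower numbers for stronger inhibition. Compound 1 `COC(=O)c1cccc(Nc2ncnc3ccc(NC(=O)Nc4ccc(CN5CCN(C)CC5)cc4)cc23)c1` gives 5630 nM. Compound 2 `O=C(Nc1ccc(CN2CCCC2)cc1)Nc1ccc2ncnc(Nc3cccc(C(F)(F)F)c3)c2c1` gives 1360 nM, the lower of the two numbers, and its gap to compound 1 lies beyond the usual scatter. Compound 3 `CCN(CC)c1ccc(NC(=O)Nc2ccc3ncnc(Nc4cccc(C(F)(F)F)c4)c3c2)cc1` is compound 2 with diethylamino in place of (pyrrolidin-1-yl)methyl on an aromatic carbon. Among the measured compounds shown here, no pair of measured compounds shows this change, so the expectation rests on compound 2 alone. In this assay compound 3 is expected to give 2000 nM, within 700 nM to 6000 nM. The expected step is a 1.5-fold higher number from compound 2 to compound 3 (0.17 log units; within the scatter), which would stay within the scatter.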

Compound 3, half-maximal inhibitory concentration: 6460 nM
The estimate for compound 3 lay 3.2-fold (0.51 log units) below the measured number, and the stated range ends below it.
By their numbers in this assay, from the lowest: compound 2; then compounds 1 and 3 (each within the scatter of the next).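

In this assay, diethylamino in place of (pyrrolidin-1-yl)methyl brings a 4.8-fold higher number from compound 2 to compound 3 (0.68 log units; beyond the scatter), so the number does respond to what sits on this aromatic carbon, even though both groups count one nitrogen and one hydrogen-bond acceptor. The change does two things at once: it removes the ring and it removes the methyl link to the aromatic ring. No measurement at hand explains the step. Which of these two differences matters remains open; a diethylaminomethyl group or a pyrrolidin-1-yl group set directly on the aromatic carbon would separate them.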